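Swapping the aryl group on a beta-lactam antiproliferative scaffold

The compounds below may be only part of what the source reports. "The series", "measured", "known", "first", "only" and "open" are said of these compounds alone.

Two compounds share a four-membered ring that carries a phenoxy group and a trimethoxyphenyl group on its nitrogen, and differ only in the aryl group on one saturated ring carbon. Compound 1 `COc1cc([C@@H]2[C@H](Oc3ccccc3)C(=O)N2c2cc(OC)c(OC)c(OC)c2)cc(OC)c1OC` bears a 3,4,5-trimethoxyphenyl there, and in a functional assay on MCF7 cells (Homo sapiens) for antiproliferative activity, read by MTT assay, with stated times of 24 h and 72 h (a lower number here means a stronger inhibitor, a higher number a weaker inhibitor), compound 1 gives 29000 nM. Compound 2 `COc1cc(N2C(=O)[C@@H](Oc3ccccc3)[C@H]2c2cccc([N+](=O)[O-])c2)cc(OC)c1OC` bears a 3-nitrophenyl instead, and in this assay compound 2 gives 30000 nM. Compound 2 stands highest of the two numbers, though its nearest neighbour is compound 1 and the gap, a 1.0-fold higher number from compound 1 to compound 2 (0.01 log units; within the scatter), lies within the scatter.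

Compound 3 `COc1cc(N2C(=O)[C@@H](Oc3ccccc3)[C@H]2c2ccc([S+](C)[O-])cc2)cc(OC)c1OC` carries the change a group of 9 heavy atoms (7 carbon, 1 oxygen, 1 sulfur; one six-membered aromatic ring of carbon only) in place of a group of 9 heavy atoms (6 carbon, 1 nitrogen, 2 oxygen; one six-membered aromatic ring of carbon only), on a saturated ring carbon

Among the compounds with values here, this is the only step so far at the same ring carbon, and it changed the number by no more than the scatter. Replacing one aryl group at that position by another of the same size is therefore expected to leave compound 3 close to compound 2, with a step of no change at the digits printed from compound 2 to compound 3 (within the scatter) expected. Compound 3 is thus estimated at 30000 nM, with a range from 10000 nM to 90000 nM.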

Compound 3, half-maximal inhibitory concentration: 20000 nM
The estimate for compound 3 lay 1.5-fold (0.18 log units) above the measured number; the range from low to high includes it.
By their numbers in this assay, from the lowest: compounds 3, 1 and 2 (each within the scatter of the next).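

Compound 3 brings a third aryl group to this ring carbon, with one sulfur and one oxygen in place of the nitrogen and two oxygens of the 3-nitrophenyl and one hydrogen-bond acceptor in place of two, and this assay shows a 1.5-fold lower number from compound 2 to compound 3 (0.18 log units; within the scatter) for this change. Set against the larger group of compound 1, which has 12 heavy atoms where the new group has 9, the same group gives a 1.5-fold lower number from compound 1 to compound 3 (0.16 log units; within the scatter), so across these three compounds neither the make-up nor the size of the aryl group separates the numbers beyond the usual scatter. Nothing available here bears on why these three groups give such similar numbers.

From the compounds shown here alone, all three compounds keep a six-membered aromatic carbon ring at this position, so it remains open whether a group without that ring, such as an amine, a carboxylic acid or a longer alkyl chain, would give a different number. The compounds shown also leave open whether any replacement at this ring carbon can move the number beyond the scatter, in either direction.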